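Oxime ether chain end: hydroxy to pyrrolidinyl

The compounds below may be only part of what the source reports. "The series", "measured", "known", "first", "only" and "open" are said of these compounds alone.

Measured so far in a functional assay on HUVEC cells (Homo sapiens) for antiproliferative activity, read by CCK-8 assay, with a stated time of 120 h; a lower number here means a stronger inhibitor, a higher number a weaker inhibitor:
compound 1, `Nc1ncnc(Oc2ccc(NC(=O)C3(C(=O)Nc4ccc(F)cc4)CC3)cc2F)c1/C=N/O`: 260 nM
compound 2, `Nc1ncnc(Oc2ccc(NC(=O)C3(C(=O)Nc4ccc(F)cc4)CC3)cc2F)c1/C=N/OCCCO`: 210 nM
compound 3, `CNc1ncnc(Oc2ccc(NC(=O)C3(C(=O)Nc4ccc(F)cc4)CC3)cc2F)c1/C=N/OC`: "not determined" (no result reported)
compound 4, `Nc1ncnc(Oc2ccc(NC(=O)C3(C(=O)Nc4ccc(F)cc4)CC3)cc2F)c1/C=N/OCCCN1CCCC1`: to be measured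

Among the measured compounds shown here, compound 2 has the lowest of the two numbers in this assay, but the only step between them, a 1.2-fold lower number from compound 1 to compound 2 (0.09 log units; within the scatter), lies within the scatter, so compound 1 and compound 2 are not separated. Compound 3 carries no result, so it adds nothing to the picture.

Compound 4 differs from compound 2 in one place: pyrrolidin-1-yl in place of hydroxy on a saturated chain carbon, three bonds along the chain from an oxygen. For the measured compounds named here, no measured step covers a change of this kind. Going by the values given here, the single step available, a 1.2-fold lower number from compound 1 to compound 2 (0.09 log units; within the scatter), also touches the chain on the oxygen of the oxime, and it is within the scatter; it gives no ground for expecting a shift in either direction in this assay beyond the scatter.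

For compound 4 the number expected in this assay is therefore close to that of compound 2, estimated at 200 nM with a range of 80 nM to 500 nM. The step this estimate implies, a 1.1-fold lower number from compound 2 to compound 4 (0.02 log units; within the scatter), is expected to stay within the scatter.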

Compound 4, half-maximal inhibitory concentration: 219 nM
Estimate against measurement, compound 4: 1.1-fold (0.04 log units) below, within the range that was stated.
By their numbers in this assay, from the lowest: compounds 2, 4 and 1 (each within the scatter of the next).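

In this assay, the end of the oxime ether chain accepts pyrrolidin-1-yl, with its five-membered non-aromatic ring and no hydrogen-bond donor, in place of hydroxy, giving a 1.0-fold higher number from compound 2 to compound 4 (0.02 log units; within the scatter). Measured against the free oxime, 3-(pyrrolidin-1-yl)propyl in place of hydrogen on the oxygen gives a 1.2-fold lower number from compound 1 to compound 4 (0.07 log units; within the scatter), so hydrogen, 3-hydroxypropyl and 3-(pyrrolidin-1-yl)propyl on this oxygen remain unseparated. Among these compounds, the hydrogen-bond donor of the hydroxy is therefore not required to keep the number within the scatter, and nothing available explains this result.

Open, on these data alone, is whether a longer or shorter chain carrying the same pyrrolidine would stay within the scatter. Also open, as far as these compounds go, is whether a morpholine, a dimethylamino group or a carboxylic acid at the chain end would separate from compound 2.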